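The source may hold more compounds than are shown below. What is called first, only, known or untested is meant among the compounds shown, and "the series" means these compounds.

Working notes on the series in an ADME assay on microsomes from liver (Homo sapiens) for metabolic stability; a lower number here means that the compound disappears faster, a higher number that the compound lasts longer.

Compound 1 `CCCNC(=O)C1CCN(C(=O)c2cc3ccsc3n2Cc2ccc(OC)cc2)CC1` gives 0.068 h in this assay. Compound 2 `CCCNC(=O)[C@@H]1C[C@H]2CCC[C@@H](C1)[C@@H]2NC(=O)c1cc2scnc2n1Cc1ccc(OC)cc1` gives 0.743 h, and compound 3 `CCCNC(=O)[C@@H]1C[C@H]2CCC[C@@H](C1)[C@@H]2NC(=O)c1cc2sc(Br)nc2n1Cc1ccc(OC)cc1` gives 0.867 h. The difference between the core of compound 1 and the core of compound 2 is not broken down here. Compound 3 arises from compound 2 by bromo in place of hydrogen on an aromatic carbon, a change that gave a 1.2-fold higher number from compound 2 to compound 3 (0.07 log units; within the scatter).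

Compound 4 `CCCNC(=O)C1CCN(C(=O)c2cc3cc(Br)sc3n2Cc2ccc(OC)cc2)CC1` is not yet measured; it arises from compound 1 by bromo in place of hydrogen on an aromatic carbon. This is the same kind of change, not the same: here the five-membered aromatic ring holds one sulfur and the carbon is next to the ring sulfur, whereas in compound 2 and compound 3 the ring holds one nitrogen and one sulfur and the carbon is next to the ring nitrogen and next to the ring sulfur.

Because the step of a 1.2-fold higher number from compound 2 to compound 3 (0.07 log units; within the scatter) lay within the scatter, the expected step is a 1.2-fold higher number from compound 1 to compound 4 (0.07 log units; within the scatter), resting on compound 1 at 0.068 h. Compound 4 is therefore estimated at 0.08 h, between 0.04 h and 0.17 h.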

Compound 4, half-life: 0.127 h
Compound 4: middle estimate off by 1.6-fold (0.20 log units), on the low side; low and high end bracket the measured number.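

In this assay, bromo in place of hydrogen on an aromatic carbon gives a 1.9-fold higher number from compound 1 to compound 4 (0.27 log units; within the scatter). The steps on the two cores cannot be told apart: the same change on two cores in this assay, a 1.2-fold higher number (0.07 log units; within the scatter) from compound 2 to compound 3 and a 1.9-fold higher number (0.27 log units; within the scatter) from compound 1 to compound 4, 1.6-fold (0.20 log units) apart, within the scatter of two such steps. This shows that the bromo step stayed within the scatter on both cores, but it does not show that the two carbons behave alike, as each stands in a different ring, and two pairs set no rule for the series.

As far as these compounds go, whether chloro, methyl or a nitrile on the same carbon would read the same as bromo remains open. Also open, from the compounds shown here alone, is whether the bromo step would hold on compounds carrying an amine or a carboxylic acid elsewhere in the molecule.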